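The compounds below may be only part of what the source reports. "The series", "measured", "known", "first", "only" and "open" are said of these compounds alone.

Compound 1 `COC(=O)CC(=O)N1N=C(c2ccc(N3CCN(C)CC3)cc2)CC1c1ccc(N(C)C)cc1` gives the lowest number of the three measured compounds in a functional assay on NCI-H1975 cells (Homo sapiens) for inhibition, read by sulforhodamine B assay, tested at 10 uM (on this read-out lower numbers stand for less inhibition and higher numbers for more inhibition at the one concentration tested (going by the name of the read-out)), where compound 1 gives -2.2%. Compound 2 `CN1CCN(c2ccc(C3=NN(S(=O)(=O)c4ccc(Br)cc4)C(c4ccc(N(C)C)cc4)C3)cc2)CC1` gives 70.8%, and compound 3 `CN1CCN(c2ccc(C3=NN(S(=O)(=O)c4ccc(C(F)(F)F)cc4)C(c4ccc(N(C)C)cc4)C3)cc2)CC1` gives 18.9%. Compound 4 `CN1CCN(c2ccc(C3=NN(S(=O)(=O)c4ccc(C#N)cc4)C(c4ccc(N(C)C)cc4)C3)cc2)CC1` differs from compound 1 in a single place: (4-cyanophenyl)sulfonyl in place of ((methoxycarbonyl)methyl)carbonyl on an amine nitrogen in a ring. Within the data shown here, two measured steps bear on this change. The step of a number 73 percentage points higher from compound 1 to compound 2 (beyond the scatter) is large and runs toward more inhibition, while the step of a number 51.9 percentage points lower from compound 2 to compound 3 (beyond the scatter) is large and runs the other way, so the outcome depends on which group sits on that phenyl ring. Among the measured compounds shown here, no measured compound carries a nitrile, so the size of the rise is uncertain. A large rise is nonetheless expected, with the step of a number 42.2 percentage points higher from compound 1 to compound 4 (beyond the scatter). Compound 4 is estimated at 40%, within a range from 10% to 70%.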

Compound 4, a percentage reported as inhibition, at one concentration (the size of the read-out at that concentration, not a potency): 100%
For compound 4 the middle estimate is 60 percentage points below the measured one, outside the stated range (above it).
By their numbers in this assay, from the lowest: compound 1; then compound 3; then compound 2; then compound 4.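

With (4-cyanophenyl)sulfonyl on the ring nitrogen, the reading in this assay is a number 102.2 percentage points higher from compound 1 to compound 4 (beyond the scatter). Among the three sulfonyl compounds, the group on the phenyl ring strongly sets the level: cyano gives a number 81.1 percentage points higher from compound 3 to compound 4 (beyond the scatter) against trifluoromethyl and a number 29.2 percentage points higher from compound 2 to compound 4 (beyond the scatter) against bromo. Nothing available explains why these groups differ so much. As far as these compounds go, it remains open whether a methoxy group or an amine on that phenyl ring would read closer to cyano or to trifluoromethyl. Also open, from the compounds shown here alone, is how compound 4 would behave at lower concentrations.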